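Isopropylsulfanyl in place of the ether on the core

The compounds below may be only part of what the source reports. "The series", "measured", "known", "first", "only" and "open" are said of these compounds alone.

Compound 1, `COCCOc1nc(N)nc2c1ncn2/C=C1/CC1(CO)CO`: in an ADME assay on CCRF-HSB-2 cells (Homo sapiens) for cytotoxicity, with a stated time of 7 days (a higher number here means that more compound is tolerated, a lower number that less compound is tolerated), compound 1 gives > 20000 nM.
Compound 2, `Nc1nc(N2CCCC2)c2ncn(/C=C3/CC3(CO)CO)c2n1`: in this assay compound 2 gives > 20000 nM.
Compound 3, `CCCCCCCCSc1nc(N)nc2c1ncn2/C=C1/CC1(CO)CO`: in this assay compound 3 gives 60000 nM.

The value of compound 1 is a limit of this assay, not a number. The value of compound 2 is likewise a limit. Among the measured compounds shown here, compound 3 carries the only number in the set, and it lies past (the limit of > 20000 nM in this assay, at which 2 of the 3 values shown sit). Compound 1 therefore stands at the tolerated edge of what this assay reports, together with one other compound, and nothing places it above or below them.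

Compound 4 is `CC(C)Sc1nc(N)nc2c1ncn2/C=C1/CC1(CO)CO`. It differs from compound 1 in one place: isopropylsulfanyl in place of 2-methoxyethoxy on an aromatic carbon. The nearest measured step is a step that the limit leaves unreadable from compound 1 to compound 3, which also exchanges the ether for a thioether but a longer one; the steps a step that the two limits leave unreadable from compound 1 to compound 2 and a step that the limit leaves unreadable from compound 2 to compound 3 are equally unreadable. For the measured compounds named here, no measured step gives a readable size, so no step beyond the scatter is expected in this assay in either direction. Compound 4 is therefore estimated at 40000 nM, between 15000 nM and 120000 nM, which amounts to an expected step that the limit leaves unreadable from compound 1 to compound 4, most likely reported again only as a limit.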

Compound 4, half-maximal cytotoxic concentration: 94000 nM
For compound 4 the middle estimate is 2.4-fold (0.37 log units) below the measured one; measured number inside the range.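

In this assay, among the compounds shown here, the result gives this position a second measured thioether, so the chain on the sulfur can now be compared for the first time: a 1.6-fold higher number from compound 3 to compound 4 (0.19 log units; within the scatter). Exchanging octyl for isopropyl on the sulfur, at the carbon next to the ring nitrogen, therefore leaves no readable difference between compound 3 and compound 4, although the two chains differ widely in length. The steps from compound 1 and from compound 2 to compound 4 cannot be read, because those two compounds carry limits and not numbers, so the exchange of 2-methoxyethoxy or pyrrolidin-1-yl for isopropylsulfanyl has no size: the limit of > 20000 nM in this assay, at which 2 of the 4 values shown sit.

As far as these compounds go, it remains open how the ether of compound 1 and the pyrrolidin-1-yl of compound 2 compare with the two thioethers, since neither has a number that could be set against them. From the compounds shown here alone, it also remains open whether the absence of a readable difference holds for other groups on the sulfur, such as methyl or benzyl, or for a primary amine at this position.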